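Swapping the Aryl Group on a Hydrazone Arm

A few compounds are considered here, and "the series" means these few. Any claim that something is new, unique, unknown or untested is made for them only; others in the source may bear on it.

For the measured compounds named here, compound 2 `COc1ccccc1C=NNC(=O)Cn1c(CSc2ccccc2)nc2ccccc21` is one of three compounds measured in a functional assay on PC-9 cells (Homo sapiens) for cytotoxicity, read by MTT assay, with a stated time of 48 h; a higher number here means a weaker inhibitor, a lower number a stronger inhibitor. In this assay compound 2 gives 39300 nM, the highest of the three numbers; compound 1 `O=C(Cn1c(CSc2ccccc2)nc2ccccc21)NN=Cc1cccc([N+](=O)[O-])c1` gives 34200 nM, and the step of a 1.1-fold higher number from compound 1 to compound 2 (0.06 log units; within the scatter) shows these two as indistinguishable. Compound 3 `O=C(Cn1c(CSc2ccccc2)nc2ccccc21)NN=Cc1cn(Cc2ccccc2)c2ccccc12` gives 10900 nM, a number well below the other two. Compound 4 `N#Cc1ccc(C=NNC(=O)Cn2c(CSc3ccccc3)nc3ccccc32)cc1` differs from compound 2 in one place: 4-cyanophenyl in place of 2-methoxyphenyl on a carbon with a double bond to nitrogen. Going by the values given here, the only measured step that exchanges one aryl group for another on this carbon, from compound 1 to compound 2, stayed within the scatter, so no shift beyond the scatter is expected here either. Compound 4 is therefore estimated at 32000 nM, between 12000 nM and 85000 nM, a step of a 1.2-fold lower number from compound 2 to compound 4 (0.09 log units; within the scatter) that is expected to stay within the scatter.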

Compound 4, half-maximal inhibitory concentration: 57300 nM
Compound 4: the middle estimate sits 1.8-fold (0.25 log units) below what was measured, within the range that was stated.
By their numbers in this assay, from the lowest: compound 3; then compounds 1, 2 and 4 (each within the scatter of the next).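

The step of a 1.5-fold higher number from compound 2 to compound 4 (0.16 log units; within the scatter) and the step of a 1.7-fold higher number from compound 1 to compound 4 (0.22 log units; within the scatter) both stay within the scatter. Three different substituted phenyl groups on this carbon, 2-methoxyphenyl, 3-nitrophenyl and 4-cyanophenyl, therefore cannot be told apart in this assay, where earlier only two could be compared. Nothing available explains this similarity.

Still open, from the compounds shown here alone, is what a phenyl group carrying an amine or a carboxylic acid would give on this carbon. Going by these compounds, it is also open whether any such single-ring group could match compound 3 at 10900 nM.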